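Trimming One Methoxy From the Weakest Anilines

The source may hold more compounds than are shown below. What is called first, only, known or untested is meant among the compounds shown, and "the series" means these compounds.

Compounds measured so far:
compound 1, `COc1ccc(-c2nn3cc(-c4cccc(N)c4)nc3s2)cc1OC`: 14000 nM
compound 2, `C=C(Br)C(=O)Nc1cccc(-c2cn3nc(-c4ccc(OC)c(OC)c4)sc3n2)c1`: 380 nM
compound 3, `C=C(Br)C(=O)Nc1cccc(-c2cn3nc(-c4ccc(OCC)cc4)sc3n2)c1`: 1400 nM

In a functional assay on CCRF-CEM cells (Homo sapiens) for inhibition, read by cell counting, with a stated time of 3 days (on this read-out lower numbers stand for stronger inhibition and higher numbers for weaker inhibition), compound 1 gives the highest number of the three, 14000 nM. The nearest measured neighbour is compound 3, which gives 1400 nM, and the furthest is compound 2 at 380 nM. The gap between compound 1 and compound 2, a 37-fold lower number from compound 1 to compound 2 (1.57 log units; beyond the scatter), comes from a (1-bromoethenyl)carbonyl in place of hydrogen on a nitrogen on an aromatic ring and therefore says nothing directly about the change studied here.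

Compound 4, `COc1cccc(-c2nn3cc(-c4cccc(N)c4)nc3s2)c1`, differs from compound 1 in one place: hydrogen in place of methoxy on an aromatic carbon, on an aromatic carbon of a six-membered aromatic ring of carbon only, ortho to a methoxy group. Going by the values given here, the only measured step that touches this part of the shared core is a 3.7-fold higher number from compound 2 to compound 3 (0.57 log units; beyond the scatter), where a 4-ethoxyphenyl replaced the 3,4-dimethoxyphenyl; it is not the same change, but it is the closest guide available. On that basis compound 4 is expected to give a somewhat higher number than compound 1, a modest step of about a 2.1-fold higher number from compound 1 to compound 4 (0.33 log units; beyond the scatter). The estimate for compound 4 in this assay is 30000 nM, with a range from 12000 nM to 70000 nM.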

Compound 4, half-maximal inhibitory concentration: > 250000 nM
Compound 4 gave a limit, no number; the forecaster's own chance of this, stated with the estimate: 25%; middle value at least 8.3-fold (0.92 log units) away from the limit.
By their numbers in this assay, from the lowest: compound 2; then compound 3; then compound 1. At a limit, above all of these: compound 4.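

Compound 4 gave a limit of the assay and not a number in this assay: the limit of > 250000 nM in this assay, at which 1 of the 4 values shown sits. As far as these compounds go, replacing the methoxy, para to a large group and ortho to a methoxy group, with hydrogen is an at least 17-fold higher number from compound 1 to compound 4 (1.25 log units; beyond the scatter), so this single position on the aromatic ring carries a large step in the compounds with the free aromatic amine, and its true size stays unknown. Going by these compounds alone, the only earlier step at this part of the molecule, a 3.7-fold higher number from compound 2 to compound 3 (0.57 log units; beyond the scatter), was modest, and it exchanged 3,4-dimethoxyphenyl for 4-ethoxyphenyl in compounds carrying the (1-bromoethenyl)carbonyl group, so it did not show what loss of this methoxy alone does.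

From the compounds shown here alone, whether the same replacement would cost as much in a compound carrying the (1-bromoethenyl)carbonyl group on the nitrogen remains open. Going by these compounds, it is also open whether a hydroxyl group, a chlorine atom or a longer chain such as propoxy at this position would keep a number within the range of the assay.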